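Pyridyl for Amide on an Oxazole Ketone

This account rests on a few compounds, and the source may have more. Where it says the series, first, only, none or still open, it means among the compounds named here.

The compounds here are ketones tested as inhibitors in an assay on HEK-293T cells for inhibition of diacylglycerol lipase-alpha (Homo sapiens), read by colorimetric assay; a lower number here means a stronger inhibitor, a higher number a weaker inhibitor. Compound 1 `O=C(CCCCCc1ccccc1)c1nc2c(F)cccc2o1` gives 117 nM in this assay and is the only one of the three with a value inside the measurable range. Compound 2 `O=C(CCCCCCc1ccccc1)c1nnc(-c2ccco2)s1` reaches only the limit of the assay, at > 10000 nM. Compound 3 `CN(C)C(=O)c1cnc(C(=O)CCCCCCc2ccccc2)o1` likewise comes back as a limit, > 10000 nM, so no number is known for it. It stands at the limit of > 10000 nM in this assay, at which 2 of the 3 values shown sit, and because only a limit is known for compound 3 and for compound 2, no order between these two can be read from the numbers shown.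

Compound 4 `Cc1ccc(-c2cnc(C(=O)CCCCCCc3ccccc3)o2)nc1` differs from compound 3 in one place: 5-methylpyridin-2-yl in place of dimethylcarbamoyl on an aromatic carbon. For the measured compounds named here, no step between two measured compounds is available, so the size of the step from compound 3 to compound 4 cannot be read from a comparable pair; the one measurable value, that of compound 1, belongs to a differently built core.

The author expects the change to move the value into the measurable range, the expected step being an at least 10-fold lower number from compound 3 to compound 4 (1.00 log units; beyond the scatter) toward stronger inhibition. Compound 4 is therefore estimated at 1000 nM, with a range from 200 nM to 5000 nM.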

Compound 4, half-maximal inhibitory concentration: > 10000 nM
Compound 4: no number, only a limit; the forecaster's own chance of this, stated with the estimate: 30%; middle value at least 10-fold (1.00 log units) away from the limit.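

Compound 4 gives > 10000 nM, which is a limit and not a number. Compound 3 also stands at a limit, so no step can be read between compound 3 and compound 4: the limit of > 10000 nM in this assay, at which 3 of the 4 values shown sit. The compounds shown leave open whether 5-methylpyridin-2-yl in place of dimethylcarbamoyl changes inhibition at all, and in which direction.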